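Replacing 4-Acetylphenyl with Pyridin-2-yl on the Ring Nitrogen

A few compounds are considered here, and "the series" means these few. Any claim that something is new, unique, unknown or untested is made for them only; others in the source may bear on it.

Measured in a functional assay on HT-29 cells (Homo sapiens) for antiproliferative activity, read by MTT assay, with a stated time of 72 h; a lower number here means a stronger inhibitor, a higher number a weaker inhibitor:
- Compound 1 `Cc1ccc(N2CCN(C(=S)SCc3ccc4nc(N)nc(N)c4c3)CC2)c(C)c1`: 2970 nM
- Compound 2 `CC(=O)c1ccc(N2CCN(C(=S)SCc3ccc4nc(N)nc(N)c4c3)CC2)cc1`: 2280 nM

Among the measured compounds shown here, compound 2 stands level with the only other measured compound, and the step between them is small: a 1.3-fold lower number from compound 1 to compound 2 (0.11 log units; within the scatter). For the measured compounds named here, that step changed the group on the same ring nitrogen, so it is the only guide here. Compound 3 `Nc1nc(N)c2cc(CSC(=S)N3CCN(c4ccccn4)CC3)ccc2n1` carries pyridin-2-yl in place of 4-acetylphenyl on an amine nitrogen in a ring. Going by the values given here, no pyridin-2-yl compound has been measured yet, so no change beyond the scatter is expected in this assay. The expected step is a 1.1-fold higher number from compound 2 to compound 3 (0.04 log units; within the scatter). For compound 3, the estimated value is 2500 nM, with an expected range from 1000 nM to 6000 nM.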

Compound 3, half-maximal inhibitory concentration: 6200 nM
Estimate against measurement, compound 3: 2.5-fold (0.39 log units) below; measured number above the stated range.
By their numbers in this assay, from the lowest: compounds 2 and 1 (each within the scatter of the next); then compound 3.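

Measured in this assay the group on this ring nitrogen can move the number after all: the earlier swap stayed within the scatter, whereas pyridin-2-yl gives a 2.7-fold higher number from compound 2 to compound 3 (0.43 log units; beyond the scatter) and a 2.1-fold higher number from compound 1 to compound 3 (0.32 log units; beyond the scatter) and both steps are modest. That makes compound 3 the weakest of the three, so not every aromatic ring is equivalent here.

This change both puts a nitrogen into the ring and removes the acetyl or methyl groups, and a plain unsubstituted phenyl would be needed to separate these two differences. Nothing available explains the rise.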